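This account rests on a few compounds, and the source may have more. Where it says the series, first, only, none or still open, it means among the compounds named here.

Compound 1 `O=C(O)C(=O)CC(=O)c1ccc(-c2ccccc2)cc1`: 3500 nM in an assay on isolated protein for inhibition of Flap endonuclease 1 (Homo sapiens); a lower number here means a stronger inhibitor, a higher number a weaker inhibitor
Compound 2 `O=C(O)C(=O)CC(=O)c1ccc(Oc2ccccc2)cc1`: 1750 nM

Of the compounds shown here, two share one core and have been measured in this assay. Compound 1 has the highest of the two numbers; its nearest neighbour is compound 2, and the step of a 2.0-fold lower number from compound 1 to compound 2 (0.30 log units; within the scatter) lies within the usual scatter, so the two cannot be ranked against each other.

Compound 3 `O=C(CC(=O)c1nnn[nH]1)c1ccc(-c2ccccc2)cc1` is not yet measured. It differs from compound 1 in one place: 1H-tetrazol-5-yl in place of carboxy on a carbonyl carbon. Among the measured compounds shown here, the only measured step, from compound 1 to compound 2, changes a group on an aromatic carbon, not the carbonyl end of the chain, so no measured step speaks to this change. The expectation for compound 3 in this assay therefore rests on compound 1 alone, and the step of no change at the digits printed from compound 1 to compound 3 (within the scatter) is estimated to stay near zero, with a wide range. Compound 3 is expected at about 3500 nM, between 800 nM and 15000 nM.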

Compound 3, half-maximal inhibitory concentration: > 100000 nM
Compound 3: no number, only a limit (the forecaster's own chance of this, stated with the estimate: 15%); at least 28-fold (1.45 log units) between middle value and limit.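

In this assay, among the compounds shown here, the carbonyl end of the chain turns out to matter far more than the earlier compounds could show: 1H-tetrazol-5-yl in place of carboxy gives an at least 28-fold higher number from compound 1 to compound 3 (1.45 log units; beyond the scatter). For the compounds shown here, the entry for compound 3 is a limit and not a number, so the step gives only a minimum size: the limit of > 100000 nM in this assay, at which 1 of the 3 values shown sits. The only earlier step, a swap of groups on an aromatic carbon, stayed within the scatter, so this is the first change here with a clear effect, and on this core 1H-tetrazol-5-yl does not stand in for carboxy.

From the compounds shown here alone, whether a methyl ester or an amide in this place would keep the inhibition of compound 1 remains open. So does whether the same swap on compound 2 would cost as much.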